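Ethyl to methyl on compound 1: expected cytotoxicity

A few compounds are considered here, and "the series" means these few. Any claim that something is new, unique, unknown or untested is made for them only; others in the source may bear on it.

For the measured compounds named here, compound 1 (`CCc1ccc(NC(=O)Nc2cc(C)nc3ccccc23)cc1`) gives 17000 nM in an ADME assay on HepG2 cells (Homo sapiens) for cytotoxicity, with a stated time of 72 h (a higher number here means that more compound is needed for the effect, a lower number that less compound is needed), the only actual number in this small set. Compound 2 (`Cc1cc(NC(=O)Nc2cccc(C(N)=O)c2)c2ccccc2n1`) reads > 25000 nM, which is a limit of the assay. Compound 3 (`COc1ccc(NC(=O)Nc2cc(C)nc3ccccc23)cc1OC`) reads > 25000 nM, which is also a limit. The set as a whole therefore shows (the limit of > 25000 nM in this assay, at which 2 of the 3 values shown sit).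

Compound 4 (`Cc1ccc(NC(=O)Nc2cc(C)nc3ccccc23)cc1`) departs from compound 1 in one place: hydrogen in place of methyl on a saturated chain carbon bound to an aromatic carbon. This is hydrogen in place of methyl on a saturated chain carbon bound to an aromatic carbon, or ethyl to methyl when cut one bond further out. Going by the values given here, no measured pair in the set isolates this change, so the expectation rests on compound 1 at 17000 nM alone. No step beyond the usual scatter is expected in this assay, and no direction can be called with confidence. The expected step, a 1.2-fold higher number from compound 1 to compound 4 (0.07 log units; within the scatter), is small. In this assay the estimate for compound 4 is 20000 nM, with an expected range of 11000 nM to 32000 nM.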

Compound 4, half-maximal effective concentration: > 25000 nM
Compound 4 gave a limit, no number; the forecaster's own chance of this, stated with the estimate: 35%; middle value at least 1.2-fold (0.09 log units) away from the limit.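

Across the ethyl to methyl change, this assay now gives its first step between two compounds that differ in one place, an at least 1.4-fold higher number from compound 1 to compound 4 (0.16 log units; that floor lies within the scatter). Compound 4 reads as a limit of the assay and not as a number, so only the floor of this step is known, and that floor does not show the change at this place to matter beyond the scatter. For the compounds shown here, compound 1 remains the only compound with an actual number, and the rest of the set sits at one value: the limit of > 25000 nM in this assay, at which 3 of the 4 values shown sit.

Going by these compounds, the true size of the step stays open, as does any value for compound 4 itself. Also open, on these data alone, is whether a longer chain such as propyl, an amine or a carboxylic acid at this place would give a number instead of a limit.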